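Replacing an amide by an aniline on a thiazole nitrogen

The compounds below may be only part of what the source reports. "The series", "measured", "known", "first", "only" and "open" are said of these compounds alone.

Measured compounds in a functional assay on WI-38 VA13 cells (Homo sapiens) for cytotoxicity; on this read-out higher numbers stand for an effect only at larger amounts of compound and lower numbers for an effect already at smaller amounts:
compound 1 `CCC(C)(C)C(=O)Nc1ccc2nc(NC(=O)C3CCCCC3)sc2c1`: 1 ug/mL
compound 2 `Cc1cc(C(=O)Nc2ccc3nc(NC(=O)C4CCCCC4)sc3c2)n(C)n1`: 0.12 ug/mL
compound 3 `CCCCCCCC(=O)Nc1nc2ccc(NC(=O)c3c(Cl)cccc3Cl)cc2s1`: 0.18 ug/mL

Among these three numbers compound 3 stands second highest; compound 2 lies nearest, within the scatter, while compound 1 lies furthest, beyond it. Among the measured compounds shown here, the only one-place step, an 8.3-fold lower number from compound 1 to compound 2 (0.92 log units; beyond the scatter), concerns the carbonyl carbon on the opposite side of the shared core and does not touch the position varied next. Compound 4 `COc1cccc(Nc2nc3ccc(NC(=O)c4c(Cl)cccc4Cl)cc3s2)c1` differs from compound 3 as follows: 3-methoxyphenyl in place of heptylcarbonyl on a nitrogen on an aromatic ring. For the measured compounds named here, no measured pair changes this nitrogen, so the expectation rests on compound 3 alone, with wide uncertainty. Compound 4 is therefore estimated at 0.3 ug/mL, between 0.06 ug/mL and 1.5 ug/mL. This expected step, a 1.7-fold higher number from compound 3 to compound 4 (0.22 log units; within the scatter), is not assumed to exceed the scatter.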

Compound 4, half-maximal effective concentration: > 7.2 ug/mL
Compound 4: only a limit was reported; the forecaster's own chance of this, stated with the estimate: 10%; middle value at least 24-fold (1.38 log units) away from the limit.
By their numbers in this assay, from the lowest: compounds 2 and 3 (each within the scatter of the next); then compound 1. At a limit, above all of these: compound 4.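

In this assay, among the compounds shown here, the nitrogen on an aromatic ring proves sensitive to what it carries, which the earlier compounds could not show: an at least 40-fold higher number from compound 3 to compound 4 (1.60 log units; beyond the scatter). Compound 4 gives only a limit, not a number: the limit of > 7.2 ug/mL in this assay, at which 1 of the 4 values shown sits.

The compounds shown do not separate the loss of the carbonyl from the arrival of the aromatic ring, since both change in this one step. A benzoyl group or a plain heptyl chain on this nitrogen would tell these apart, and an unsubstituted phenyl would address the methoxy group.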